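A few compounds are considered here, and "the series" means these few. Any claim that something is new, unique, unknown or untested is made for them only; others in the source may bear on it.

Measured compounds and their results:

- compound 1 `Cc1cc(Nc2cc(-c3ccccc3)[nH]n2)n2nc(SCc3ccc(Cl)cc3)nc2n1`: 31800 nM
- compound 2 `Cc1nc2nc(SCc3ccc(Cl)cc3)nn2c(Nc2cc(-c3ccccc3)[nH]n2)c1C`: 47200 nM
- compound 3 `Cc1cc(Nc2ccn(Cc3ccc(C(F)(F)F)cc3)n2)n2nc(SCc3ccc(Br)cc3)nc2n1`: 30200 nM

In an ADME assay on GES1 cells (Homo sapiens) for inhibition, read by MTT assay, with a stated time of 72 h (a higher number here means a weaker inhibitor, a lower number a stronger inhibitor), compound 1 gives 31800 nM, which places it second highest of the three numbers. Its nearest neighbour is compound 3 with 30200 nM, and compound 2 with 47200 nM is the furthest; both gaps lie within the scatter, so the three compounds cannot be told apart on these numbers.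

Compound 4 `Cc1cc(Nc2cc(-c3ccccc3)[nH]n2)n2nc(SCc3ccc(Br)cc3)nc2n1` has not yet been measured. It differs from compound 1 in one place: bromo in place of chloro on an aromatic carbon.

Among the measured compounds shown here, the only measured single step, a 1.5-fold higher number from compound 1 to compound 2 (0.17 log units; within the scatter), concerns a different change and so does not bear directly on the exchange of a halogen. Compound 3 carries the bromo group but differs from compound 1 in more than one place, so its value with that of compound 1 only shows that the two sit close together. Nothing here points to a shift beyond the scatter in either direction in this assay.

Compound 4 is therefore expected to give about 30000 nM in this assay, with a range from 15000 nM to 60000 nM. For compound 4 this expectation means a 1.1-fold lower number from compound 1 to compound 4 (0.03 log units; within the scatter).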

Compound 4, half-maximal inhibitory concentration: 39300 nM
Compound 4: the middle estimate sits 1.3-fold (0.12 log units) below what was measured; the measured number falls inside the stated range.
By their numbers in this assay, from the lowest: compounds 3, 1, 4 and 2 (each within the scatter of the next).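

In this assay, bromo in place of chloro on the aromatic carbon para to a large group gives a 1.2-fold higher number from compound 1 to compound 4 (0.09 log units; within the scatter), so at this position the two halogens cannot be told apart. Among the compounds shown here, compound 3 also carries bromo but differs from compound 1 in more than one place, whereas compound 1 and compound 4 differ in this one place only, which makes this the first direct reading of the exchange. No accompanying measurement offers an explanation for this result.

The compounds shown have only chloro or bromo at this position, so it remains open whether a fluoro, a methoxy, an amine or a carboxylic acid there would give a step beyond the scatter. Going by these compounds, it is also open whether the same halogen exchange would read alike on compound 2, with its added methyl.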